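Compound 2 to compound 3: one group exchanged

The source may hold more compounds than are shown below. What is called first, only, known or untested is meant among the compounds shown, and "the series" means these compounds.

In a functional assay on SW-620 cells (Homo sapiens) for cytotoxicity, read by MTT assay, with a stated time of 72 h (on this read-out lower numbers stand for stronger inhibition and higher numbers for weaker inhibition), compound 1 `COc1cccc(/C=C2\CCC/C(=C\c3cccc(Cl)c3)C2=O)c1OC` gives 9100 nM. Compound 2 `COc1ccccc1/C=C1\CCC/C(=C\c2cccc(OC)c2OC)C1=O` gives > 20000 nM, which is a limit of the assay and not a number. Compound 2 therefore stands at the limit of > 20000 nM in this assay, at which 1 of the 2 values shown sits. Compound 3 `COc1cccc(/C=C2\CCC/C(=C\c3ccc(O)cc3)C2=O)c1OC` differs from compound 2 at one place: 4-hydroxyphenyl in place of 2-methoxyphenyl on a double-bonded chain carbon bound to a double-bonded ring carbon. Going by the values given here, one measured step bears on this, since it brought in 2-methoxyphenyl at the same place: an at least 2.1-fold higher number from compound 1 to compound 2 (0.34 log units; beyond the scatter). Losing that group is therefore expected to lower the number in this assay by a modest amount, though a single step is thin support. The expected change is an at least 2.2-fold lower number from compound 2 to compound 3 (0.34 log units; beyond the scatter). The estimate for compound 3 is 9000 nM, with an expected range from 3000 nM to 20000 nM.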

Compound 3, half-maximal inhibitory concentration: > 20000 nM
Compound 3 ended at the assay's limit; the forecaster's own chance of this, stated with the estimate: 25%; at least 2.2-fold (0.34 log units) between middle value and limit.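

In this assay compound 3 gives > 20000 nM, which is a limit of the assay and not a number. With 4-hydroxyphenyl on the double-bonded chain carbon, the series shows an at least 2.1-fold higher number from compound 1 to compound 3 (0.34 log units; beyond the scatter), so a hydrogen-bond donor on this aryl group does not match the measurable value that 3-chlorophenyl gives in compound 1. The step between compound 2 and compound 3 cannot be read, so 4-hydroxyphenyl and 2-methoxyphenyl cannot be ranked, and the read-out offers little resolution at this place: the limit of > 20000 nM in this assay, at which 2 of the 3 values shown sit.

From the compounds shown here alone, it remains open whether an amine or a carboxylic acid on this aryl ring would give a measurable value. Going by these compounds, it is also open whether chlorine specifically matters, which a bromophenyl or an unsubstituted phenyl group at the same place could address.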